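A few compounds are considered here, and "the series" means these few. Any claim that something is new, unique, unknown or untested is made for them only; others in the source may bear on it.

In a functional assay on MCF7 cells (Homo sapiens) for cytotoxicity, read by MTT assay, with a stated time of 72 h (on this read-out lower numbers stand for stronger inhibition and higher numbers for weaker inhibition), compound 1 `COc1ccc(/C=N/NC(=O)Nc2cc3c(Nc4ccc(F)c(Cl)c4)ncnc3cc2O[C@H]2CCOC2)cc1` gives 27300 nM, compound 2 `COc1ccc(/C=N/NC(=O)Nc2cc3c(Nc4ccc(F)c(Cl)c4)ncnc3cc2O[C@H]2CCOC2)c(OC)c1OC` gives 33800 nM and compound 3 `COc1cc(/C=N/NC(=O)Nc2cc3c(Nc4ccc(F)c(Cl)c4)ncnc3cc2O[C@H]2CCOC2)cc(OC)c1OC` gives 26500 nM. These three numbers cannot be told apart, so compound 3 stands level with the other two. Compound 4 `O=C(N/N=C/c1cc(Br)c(O)c(Br)c1)Nc1cc2c(Nc3ccc(F)c(Cl)c3)ncnc2cc1O[C@H]1CCOC1` differs from compound 3 by one change, 3,5-dibromo-4-hydroxyphenyl in place of 3,4,5-trimethoxyphenyl on a carbon with a double bond to nitrogen. The closest evidence comes from swaps at that same carbon: a 1.2-fold higher number from compound 1 to compound 2 (0.09 log units; within the scatter), a 1.0-fold lower number from compound 1 to compound 3 (0.01 log units; within the scatter) and a 1.3-fold lower number from compound 2 to compound 3 (0.11 log units; within the scatter), all within the scatter. None of these swaps introduces the new group, so this evidence is only indirect. In this assay, no step beyond the scatter is therefore expected, and the estimated step is a 1.1-fold lower number from compound 3 to compound 4 (0.04 log units; within the scatter). Compound 4 is estimated at 24000 nM, with an expected range of 9000 nM to 50000 nM.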

Compound 4, half-maximal inhibitory concentration: 5910 nM
Compound 4: middle estimate off by 4.1-fold (0.61 log units), on the high side, and the stated range ends above it.
By their numbers in this assay, from the lowest: compound 4; then compounds 3, 1 and 2 (each within the scatter of the next).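

Swaps among the methoxyphenyl groups at this carbon had moved nothing beyond the scatter, so the position looked insensitive to change. In this assay, 3,5-dibromo-4-hydroxyphenyl shows that it is not, with modest steps against all three earlier groups (a 4.5-fold lower number from compound 3 to compound 4 (0.65 log units; beyond the scatter); a 5.7-fold lower number from compound 2 to compound 4 (0.76 log units; beyond the scatter); a 4.6-fold lower number from compound 1 to compound 4 (0.66 log units; beyond the scatter)). No measurement here explains this difference.

The compounds shown do not tell whether the two bromine atoms, the hydroxyl group or both together go with the lower number. A 4-hydroxyphenyl or a 3,5-dibromophenyl on this carbon would separate them.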